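A few compounds are considered here, and "the series" means these few. Any claim that something is new, unique, unknown or untested is made for them only; others in the source may bear on it.

In a functional assay on KB cells (Homo sapiens) for cytotoxicity, read by resazurin assay, with a stated time of 3 days (on this read-out lower numbers stand for stronger inhibition and higher numbers for weaker inhibition), compound 1 `CCCCCCCCCCC(=O)NCC(C)(C)CC1=C(O)C(=O)c2ccccc2C1=O` gives 17600 nM. Compound 2 `CCCCCCCCCCCC(=O)NCC(C)(C)CC1=C(O)C(=O)c2ccccc2C1=O` differs from compound 1 in a single place: methyl in place of hydrogen on a saturated chain carbon, ten or more bonds along the chain from a carbonyl carbon. In this assay compound 2 gives 12800 nM, and the step of a 1.4-fold lower number from compound 1 to compound 2 (0.14 log units; within the scatter) is therefore a small one. Compound 3 `CCCCCC(=O)OCC(C)(C)CC1=C(O)C(=O)c2ccccc2C1=O` gives 41000 nM in this assay; how the core of compound 3 differs from the core of compound 1 is not broken down here. Compound 4 `CCCCCCC(=O)OCC(C)(C)CC1=C(O)C(=O)c2ccccc2C1=O` is related to compound 3 by the same kind of change, (methyl in place of hydrogen on a saturated chain carbon, five bonds along the chain from a carbonyl carbon). For compound 4 a similar small step, a 1.2-fold lower number from compound 3 to compound 4 (0.09 log units; within the scatter), is expected because the earlier step of a 1.4-fold lower number from compound 1 to compound 2 (0.14 log units; within the scatter) stayed within the scatter. Compound 4 is thus estimated at 33000 nM, with a likely range from 18000 nM to 60000 nM.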

Compound 4, half-maximal inhibitory concentration: 14400 nM
Compound 4: the middle estimate sits 2.3-fold (0.36 log units) above what was measured; the measured number lies below the stated range.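

In this assay, putting a methyl in place of a hydrogen on the chain of compound 3 gives a 2.8-fold lower number from compound 3 to compound 4 (0.45 log units; beyond the scatter), a modest step. Set beside the same change on the other core, the two steps differ by no more than the scatter allows: the same change on two cores in this assay, a 1.4-fold lower number (0.14 log units; within the scatter) from compound 1 to compound 2 and a 2.8-fold lower number (0.45 log units; beyond the scatter) from compound 3 to compound 4, 2.1-fold (0.32 log units) apart, within the scatter of two such steps. These two pairs therefore give no sign that the change behaves differently on the two cores, but two pairs cannot fix the size of the step or show that it would carry over to any further core.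

The compounds shown leave open what a longer chain would do on the core of compound 3. They also leave open how a chain carrying an amine or a carboxylic acid would fare on either core.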